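The source may hold more compounds than are shown below. What is called first, only, known or untested is meant among the compounds shown, and "the series" means these compounds.

Series notes.

Measured so far:
- compound 1 `COc1ccc(C2Oc3ccccc3N(CCCCCN3C(C)CCCC3C)C2=O)cc1`: 2.3%
- compound 2 `CC1CCCC(C)N1CCCCCN1C(=O)C(c2cccc(C(=N)NO)c2)Oc2ccccc21`: 21%
- compound 3 `CC1CCCC(C)N1CCCCCN1C(=O)C(c2ccc(C(=N)NO)cc2)Oc2ccccc21`: 8%

In an assay on isolated protein for inhibition of serine protease 1 (Homo sapiens), tested at 100 uM (a lower number here means less inhibition, a higher number more inhibition at the concentration tested (going by the name of the read-out)), compound 3 stands second highest of the three numbers. Its gap to compound 1 is within the scatter (a number 5.7 percentage points higher from compound 1 to compound 3 (within the scatter)), whereas the step of a number 13 percentage points lower from compound 2 to compound 3 (beyond the scatter) is beyond the scatter, modest in size.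

Compound 4 `CC1CCCC(C)N1CCCCCN1C(=O)C(c2cccc(C(=N)S)c2)Oc2ccccc21` has not been measured. Against compound 3 the change is a group of 9 heavy atoms (7 carbon, 1 nitrogen, 1 sulfur; one six-membered aromatic ring of carbon only) in place of a group of 10 heavy atoms (7 carbon, 2 nitrogen, 1 oxygen; one six-membered aromatic ring of carbon only), on a saturated ring carbon.

Among the compounds with values here, the steps that bear on this are those that also swap the group on the saturated ring carbon: a number 18.7 percentage points higher from compound 1 to compound 2 (beyond the scatter) and a number 13 percentage points lower from compound 2 to compound 3 (beyond the scatter), both modest, and the smaller a number 5.7 percentage points higher from compound 1 to compound 3 (within the scatter). Within the data shown here, none of the measured compounds carries the group that enters in compound 4, so no step speaks to it directly. The measured steps suggest a modest change at most in this assay, with direction uncertain.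

Compound 4 is therefore expected to give about 14%, with a range from 3% to 30%.

The expected step is a number 6 percentage points higher from compound 3 to compound 4 (within the scatter).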

Compound 4, a percentage reported as inhibition, at one concentration (the size of the read-out at that concentration, not a potency): 5.2%
The estimate for compound 4 lay 8.8 percentage points above the measured number; measured number inside the range.
By their numbers in this assay, from the lowest: compounds 1, 4 and 3 (each within the scatter of the next); then compound 2.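

In this assay, within the data shown here, sulfanyl in place of hydroxyamino on the carbon with a double bond to nitrogen gives a number 15.8 percentage points lower from compound 2 to compound 4 (beyond the scatter), the first change at that carbon itself, and the number of compound 2 does not survive it. Among these compounds, the other two steps, a number 2.8 percentage points lower from compound 3 to compound 4 (within the scatter) and a number 2.9 percentage points higher from compound 1 to compound 4 (within the scatter), stay within the scatter, so compound 2 remains the only compound whose steps to all the others are beyond the scatter. Nothing available accounts for the step from hydroxyamino to sulfanyl.

On these data alone, whether an amino or methoxy group on that same carbon would keep the number of compound 2 remains open. Also open, as far as these compounds go, is what sulfanyl would do with the aromatic ring attachment of compound 3, and, with a single tested concentration, how potency would compare.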